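A few compounds are considered here, and "the series" means these few. Any claim that something is new, unique, unknown or untested is made for them only; others in the source may bear on it.

Measured so far in an assay on isolated protein for inhibition of lysosomal alpha-glucosidase (Rattus norvegicus), read by colorimetric assay; a lower number here means a stronger inhibitor, a higher number a weaker inhibitor:
compound 1, `OC[C@@]1(c2cccc(F)c2)NC[C@@H](O)[C@@H]1O`, gives 216000 nM
compound 2, `OC[C@]1(c2c(F)c(F)c(F)c(F)c2F)NC[C@H](O)[C@H]1O`, gives 183000 nM

Compound 2 holds the lowest of the two numbers in this assay, yet its nearest neighbour is compound 1, whose number is higher by a margin that stays within the usual scatter, so the two cannot be ordered. Compound 3, `OC[C@@]1(c2c(F)c(F)c(F)c(F)c2F)NC[C@@H](O)[C@@H]1O`, has not been measured. It differs from compound 2 only in configuration: the two compounds have the same atoms and bonds and differ only in configuration as drawn: 3 of 3 stereo elements differ (all stereocentres are inverted: mirror images); a stereocentre at a saturated ring carbon is drawn S in compound 2 and R in compound 3; a stereocentre at a saturated ring carbon is drawn S in compound 2 and R in compound 3; a stereocentre at a saturated ring carbon is drawn S in compound 2 and R in compound 3. Among the compounds with values here, no step between two measured compounds of this kind is available, so there is nothing in the data to set the size or direction of a step between mirror images. Both measured values are weak, and compound 3 is expected to land in the same weak region, with a step from compound 2 of a 1.1-fold higher number from compound 2 to compound 3 (0.04 log units; within the scatter) carrying wide uncertainty. For compound 3 the estimate in this assay is 200000 nM, within a range from 40000 nM to 1000000 nM.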

Compound 3, half-maximal inhibitory concentration: 66000 nM
Compound 3: middle estimate off by 3.0-fold (0.48 log units), on the high side, within the range that was stated.
By their numbers in this assay, from the lowest: compound 3; then compounds 2 and 1 (each within the scatter of the next).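

In this assay, within the data shown here, inverting all three stereocentres gives a 2.8-fold lower number from compound 2 to compound 3 (0.44 log units; beyond the scatter), the first step in these data that lies beyond the scatter, so this assay can tell a pair of mirror images apart. The step can be assigned to configuration alone, because nothing else changes: the fact that compounds 2 and 3 differ only in the configuration as drawn The lower number is still a weak one, as compound 3 gives 66000 nM, so inversion alone does not lift this shared core out of the weak region.

From the compounds shown here alone, it remains open which of the three stereocentres carries the step, and whether the same configuration gives the lower number with the aromatic ring of compound 1. Also open, going by these compounds, is how an amine, a carboxylic acid or a longer chain on the shared core would read in this configuration.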